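The source may hold more compounds than are shown below. What is called first, only, known or untested is meant among the compounds shown, and "the series" means these compounds.

Of the compounds shown here, three that share a core have been tested in a functional assay on Shh Light II cells (Mus musculus) for inhibition, read by a luciferase reporter; on this read-out lower numbers stand for stronger inhibition and higher numbers for weaker inhibition. Compound 1 `O=C(Nc1ccccc1C(F)(F)F)N1CCC(c2nc(-c3ccc4ccccc4n3)no2)CC1` gives 700 nM. Compound 2 `COc1ccccc1N(C)C(=O)N1CCC(c2nc(-c3ccc4ccccc4n3)no2)CC1` gives 3100 nM. Compound 3 `Cn1c(-c2noc(C3CCN(C(=O)NC4CCS(=O)(=O)CC4)CC3)n2)nc2ccccc21` gives 350 nM, the lowest of the three numbers; its gap to compound 1 lies within the scatter, while its gap to compound 2 lies beyond it, so compound 3 cannot be singled out as the most potent of the set.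

Compound 4 `O=C(NC1CCS(=O)(=O)CC1)N1CCC(c2nc(-c3ccc4ccccc4n3)no2)CC1` has not yet been measured. It differs from compound 3 in a single place: quinolin-2-yl in place of 1-methyl-1H-benzimidazol-2-yl on an aromatic carbon.

Among the compounds with values here, the only measured step, a 4.4-fold higher number from compound 1 to compound 2 (0.65 log units; beyond the scatter), concerns the group on the carbonyl carbon and leaves the aromatic group untouched, so it does not speak to this change. Within the data shown here, compound 1 and compound 3 differ in two places, so no single step connects them; their numbers simply lie within the scatter of each other, and compound 1 already carries quinolin-2-yl. There is thus no measured evidence that the exchange of these two aromatic groups moves the number beyond the scatter.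

Compound 4 is therefore expected to give about 500 nM in this assay, with a likely range from 200 nM to 1500 nM. This estimate corresponds to an expected step of a 1.4-fold higher number from compound 3 to compound 4 (0.15 log units; within the scatter), which is not beyond the scatter.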

Compound 4, half-maximal inhibitory concentration: 360 nM
Compound 4: middle estimate off by 1.4-fold (0.14 log units), on the high side, and the stated range covers the measured number.
By their numbers in this assay, from the lowest: compounds 3, 4 and 1 (each within the scatter of the next); then compound 2.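

In this assay the aromatic position gets its first direct test, a 1.0-fold higher number from compound 3 to compound 4 (0.01 log units; within the scatter), so on the aromatic carbon of this five-membered ring, quinolin-2-yl and 1-methyl-1H-benzimidazol-2-yl cannot be told apart when the carbonyl carbon carries (1,1-dioxothian-4-yl)amino. The other end of the molecule now has two further single-place comparisons: a 1.9-fold lower number from compound 1 to compound 4 (0.29 log units; within the scatter), which leaves 1,1-dioxothian-4-yl and 2-(trifluoromethyl)phenyl on the amide-type nitrogen indistinguishable, whereas an 8.6-fold lower number from compound 2 to compound 4 (0.94 log units; beyond the scatter), a step beyond the scatter that shows the group on the carbonyl carbon can shift the number in this series. No available evidence explains either the match between the two aromatic groups or the larger step from compound 2.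

The compounds shown leave open whether a single-ring group such as phenyl or pyridin-2-yl on that aromatic carbon would fit the same pattern, and whether the two aromatic groups would still match with (2-(trifluoromethyl)phenyl)amino on the carbonyl carbon. The step from compound 2 also exchanges the ring and the methyl on nitrogen together, so (2-methoxyphenyl)amino would be needed to separate those two changes.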